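Clearance notes: fluorophenyl position on the shared core

The compounds below may be only part of what the source reports. "The series", "measured", "known", "first", "only" and "open" are said of these compounds alone.

Three measured compounds share a sulfonyl-bearing core. Compound 1 `COc1ccc(S(=O)(=O)c2cnc3cc(F)ccc3c2-c2cccc(F)c2)cc1Cl` in an ADME assay on microsomes from liver (Homo sapiens) for metabolic stability, tested at 2.5 uM (a higher number here means faster removal of the compound, a lower number slower removal), gives 2.08 mL/min. Compound 2 `O=S(=O)(c1cc(F)cc(F)c1)c1cnc2cc(F)ccc2c1-c1cccc(F)c1` gives 0.06 mL/min in this assay, and compound 3 `O=S(=O)(c1cc(Cl)cc(Cl)c1)c1cnc2cc(F)ccc2c1-c1ccc(F)cc1` gives 0.18 mL/min. Compound 3 therefore stands second highest of the three: the nearest is compound 2, the furthest compound 1.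

For the measured compounds named here, the only step between measured compounds, 3,5-difluorophenyl in place of 3-chloro-4-methoxyphenyl on a sulfonyl sulfur, is a 35-fold lower number from compound 1 to compound 2 (1.54 log units; beyond the scatter); it concerns the group on the sulfonyl sulfur and does not touch the change now considered.

Compound 4 `O=S(=O)(c1cc(Cl)cc(Cl)c1)c1cnc2cc(F)ccc2c1-c1cccc(F)c1` differs from compound 3 in one place: 3-fluorophenyl in place of 4-fluorophenyl on an aromatic carbon. Going by the values given here, no measured pair shows this exchange, so there is nothing to size it by; the one known step lies elsewhere. The expectation is therefore a step of no change at the digits printed from compound 3 to compound 4 (within the scatter) in this assay, not beyond the scatter. Compound 4 is thus estimated at 0.18 mL/min, within 0.07 mL/min to 0.45 mL/min.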

Compound 4, intrinsic clearance in a liver preparation (reported as CLH), per the amount of preparation that the assay uses: 0.41 mL/min
Estimate against measurement, compound 4: 2.3-fold (0.36 log units) below; measured number inside the range.
By their numbers in this assay, from the lowest: compound 2; then compound 3; then compound 4; then compound 1.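

In this assay, for the compounds shown here, the fluorine position on the aryl group at this place on the shared core is not silent: 3-fluorophenyl in place of 4-fluorophenyl gives a 2.3-fold higher number from compound 3 to compound 4 (0.36 log units; beyond the scatter) as the first reading of this exchange. With 3-fluorophenyl held constant, the group on the sulfonyl sulfur can now be compared further: 3,5-dichlorophenyl in place of 3,5-difluorophenyl gives a 6.8-fold higher number from compound 2 to compound 4 (0.83 log units; beyond the scatter) and 3,5-dichlorophenyl in place of 3-chloro-4-methoxyphenyl gives a 5.1-fold lower number from compound 1 to compound 4 (0.71 log units; beyond the scatter) as its two readings. No measured information explains any of these steps.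

Going by these compounds, whether the fluorine exchange keeps its size with another group on the sulfonyl sulfur remains open. So does the outcome of putting an amine or a carboxylic acid in place of the fluorine on this aryl group.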